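Aryl sulfanyl variation on the shared core

This account rests on a few compounds, and the source may have more. Where it says the series, first, only, none or still open, it means among the compounds named here.

Compound 3 `Nc1cc(N)c2nc(-c3ccccc3)c(Sc3ccc(F)cc3)nc2c1` sits at the lowest of the two numbers in a functional assay on NCI/ADR-RES cells (Homo sapiens) for inhibition, read by sulforhodamine B assay, with a stated time of 48 h (a lower number here means a stronger inhibitor of growth, a higher number a weaker inhibitor of growth), where compound 3 gives 34700 nM. Compound 1 `Nc1cc(N)c2nc(-c3ccccc3)c(NCc3ccc(Cl)c(Cl)c3)nc2c1` gives 45700 nM in this assay, which is within the scatter of compound 3. For compound 2 `CCOC(=O)[C@H](CCC(=O)O)NC(=O)c1ccc(Sc2nc3cc(N)cc(N)c3nc2-c2ccccc2)cc1` the result in this assay is only a limit, < 100000 nM, not a number (the limit of < 100000 nM in this assay, at which 1 of the 3 values shown sits). Compound 4 `Nc1cc(N)c2nc(-c3ccccc3)c(Sc3ccc(Cl)c(Cl)c3)nc2c1` is not yet measured and differs from compound 3 in one place (3,4-dichlorophenyl in place of 4-fluorophenyl on a sulfur). For the measured compounds named here, no measured pair isolates this change, so no step beyond the scatter is expected in either direction. Compound 4 is estimated at 30000 nM in this assay, between 10000 nM and 90000 nM, which means an expected step of a 1.2-fold lower number from compound 3 to compound 4 (0.06 log units; within the scatter). This estimate leans on compound 1, which also carries 3,4-dichlorophenyl and gives 45700 nM.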

Compound 4, concentration for total growth inhibition: 60300 nM
Compound 4: middle estimate off by 2.0-fold (0.30 log units), on the low side; the range from low to high includes it.
By their numbers in this assay, from the lowest: compounds 3, 1 and 4 (each within the scatter of the next).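

For the compounds shown here, on the sulfur of the shared core, 3,4-dichlorophenyl in place of 4-fluorophenyl gives a 1.7-fold higher number from compound 3 to compound 4 (0.24 log units; within the scatter) in this assay, and this is the first measured pair that isolates this change. At this position, the exchange of these two groups therefore does not separate the compounds beyond the scatter. No data shown bear on the cause of this step.

Open, as far as these compounds go, is whether a nitrile or a methoxy group on the phenyl ring would give a step beyond the scatter. Also open, from the compounds shown here alone, is how an oxygen in place of the sulfur would read.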